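The compounds below may be only part of what the source reports. "The series", "measured", "known", "first", "only" and "open" are said of these compounds alone.

Compound 1: `Cc1ccccc1-c1cnc(NC(=O)c2ccc(F)cc2)n1C` — > 50000 nM
Compound 2: `COc1ccc(-c2cnc(NC(=O)c3ccccn3)n2C)cc1` — > 100000 nM
Compound 3: `Cn1c(-c2ccccc2)cnc1NC(=O)c1cc(-c2ccccn2)[nH]n1` — > 50000 nM

Three compounds of this series have so far been examined in a toxicity assay on THP-1 cells (Homo sapiens) for inhibition; a lower number here means that less compound is tolerated, a higher number that more compound is tolerated. Compound 1 `Cc1ccccc1-c1cnc(NC(=O)c2ccc(F)cc2)n1C` gives > 50000 nM, which is a limit of the assay and not a number. Compound 2 `COc1ccc(-c2cnc(NC(=O)c3ccccn3)n2C)cc1` gives > 100000 nM, likewise a limit. Compound 3 `Cn1c(-c2ccccc2)cnc1NC(=O)c1cc(-c2ccccn2)[nH]n1` gives > 50000 nM, again a limit. Compound 1 therefore has no measured position among the values shown: its own result is a limit, and the two further values are limits as well, as the limit of > 50000 nM in this assay, at which 2 of the 3 values shown sit, and the limit of > 100000 nM in this assay, at which 1 of the 3 values shown sits, make plain. Among the measured compounds shown here, no pair of measured compounds differing in one place is available, so no measured step can be read from the data.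

Compound 4 `Cn1c(-c2ccc(F)cc2)cnc1NC(=O)c1ccc(F)cc1` has not yet been measured in this assay. It differs from compound 1 in a single place: 4-fluorophenyl in place of 2-methylphenyl on an aromatic carbon. With every value shown sitting at a limit, no step beyond the scatter is expected in either direction. The step that the limit leaves unreadable from compound 1 to compound 4 is thus expected to be negligible. Compound 4 is estimated to give 80000 nM, within the range 40000 nM to 200000 nM, and the result is expected most likely to come back as a limit rather than as a number.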

Compound 4, half-maximal cytotoxic concentration: > 100000 nM
Compound 4 ended at the assay's limit; the forecaster's own chance of this, stated with the estimate: 85%; middle value at least 1.2-fold (0.09 log units) from the limit.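

In this assay compound 4 gives > 100000 nM, which is a limit of the assay and not a number. Compound 1 gives > 50000 nM, likewise a limit, so no step can be read between compound 1 and compound 4. The compounds shown leave open whether 4-fluorophenyl in place of 2-methylphenyl alters the half-maximal cytotoxic concentration at all.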